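Replacing Trifluoromethyl with Methyl on an Aromatic Carbon

This account rests on a few compounds, and the source may have more. Where it says the series, first, only, none or still open, it means among the compounds named here.

- Compound 1 `CN1C(=O)CCC1(O)c1cccc(C(F)(F)F)c1`: 93.8 mg/kg
- Compound 2 `CCN1C(=O)CCC1(O)c1cccc(C(F)(F)F)c1`: > 100 mg/kg (a limit)

In a functional assay on the whole organism with Mus musculus as the target (on this read-out higher numbers stand for an effect only at larger amounts of compound and lower numbers for an effect already at smaller amounts), compound 1 holds the only exact number shown. The entry for compound 2 is a limit. Compound 3 `Cc1cccc(C2(O)CCC(=O)N2C)c1` has methyl in place of trifluoromethyl on an aromatic carbon. Within the data shown here, the only measured step, an at least 1.0-fold higher number from compound 1 to compound 2 (0.02 log units; that floor lies within the scatter), lies elsewhere in the structure and stays within the scatter, so it gives no size for this change. No shift beyond the scatter is therefore expected in this assay, in either direction. The expected step is a 1.1-fold higher number from compound 1 to compound 3 (0.03 log units; within the scatter). Compound 3 is estimated at 100 mg/kg, with an expected range of 50 mg/kg to 200 mg/kg.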

Compound 3, dose for half-maximal effect: 81.5 mg/kg
Compound 3: the middle estimate sits 1.2-fold (0.09 log units) above what was measured; low and high end bracket the measured number.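

In this assay, the exchange on the aromatic carbon gives a 1.2-fold lower number from compound 1 to compound 3 (0.06 log units; within the scatter), so trifluoromethyl and methyl cannot be told apart at this position, even though the three fluorine atoms are gone. Among these compounds, this is the first reading at this place, since the other step lies on the chain at the ring nitrogen. Compound 2 is the one entry given as a limit: the limit of > 100 mg/kg in this assay, at which 1 of the 3 values shown sits.

On these data alone, whether an amine or a carboxylic acid on this aromatic carbon would move the number beyond the scatter stays open. So does the effect of a longer chain there.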